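Swapping the aryl ether group on a tight binder

This account rests on a few compounds, and the source may have more. Where it says the series, first, only, none or still open, it means among the compounds named here.

Compound 1 `COc1cc(C(C)O)ccc1OCCCN1CCC(C(c2ccc(F)cc2)c2ccc(F)cc2)CC1`: 10 nM
Compound 2 `COc1cc(C(=O)O)ccc1OCCCN1CCC(C(c2ccc(F)cc2)c2ccc(F)cc2)CC1`: 79.4 nM
Compound 3 `Fc1ccc(OCCCN2CCC(C(c3ccc(F)cc3)c3ccc(F)cc3)CC2)cc1`: 1.26 nM

These values come from a functional assay (aorta) with Oryctolagus cuniculus as the target; on this read-out higher numbers stand for weaker binding and lower numbers for tighter binding. Compound 3 has the lowest number of the three and so binds most tightly. Compound 4 `Fc1ccc(C(c2ccc(F)cc2)C2CCN(CCCOc3cccc4ccccc34)CC2)cc1` differs from it in one place: naphthalen-1-yl in place of 4-fluorophenyl on an oxygen on a saturated carbon. That is naphthalen-1-yl in place of 4-fluorophenyl on an oxygen on a saturated carbon.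

Two measured steps change the group at this same place. The first is a 7.9-fold lower number from compound 1 to compound 3 (0.90 log units; beyond the scatter), and the second is a 63-fold lower number from compound 2 to compound 3 (1.80 log units; beyond the scatter). Both show that this group can matter, but neither involves naphthalen-1-yl. Unlike the groups in compound 1 and compound 2, naphthalen-1-yl matches 4-fluorophenyl in having no hydrogen-bond donors or acceptors, so a smaller step seems likely. Within the data shown here, a small rise is expected, since compound 3 at 1.26 nM is the lowest value so far.

The expected change is a 2.0-fold higher number from compound 3 to compound 4 (0.30 log units; within the scatter). For compound 4 the estimate is 2.5 nM, with an expected range of 0.6 nM to 10 nM.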

Compound 4, dissociation constant: 5.01 nM
Compound 4: middle estimate off by 2.0-fold (0.30 log units), on the low side, within the range that was stated.
By their numbers in this assay, from the lowest: compound 3; then compounds 4 and 1 (each within the scatter of the next); then compound 2.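

With no hydrogen-bond donors or acceptors on either group, swapping 4-fluorophenyl for naphthalen-1-yl still gives a 4.0-fold higher number from compound 3 to compound 4 (0.60 log units; beyond the scatter), so at this position the count of donors and acceptors does not settle the outcome. The naphthalen-1-yl group also gives a 16-fold lower number from compound 2 to compound 4 (1.20 log units; beyond the scatter) against the 4-carboxy-2-methoxyphenyl group, whereas the comparison with the 4-(1-hydroxyethyl)-2-methoxyphenyl group gives a 2.0-fold lower number from compound 1 to compound 4 (0.30 log units; within the scatter), so these two groups cannot be told apart here. Nothing measured here gives a reason for these differences.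

In the step from compound 3 to compound 4, the second aromatic ring arrives as the fluorine leaves, and the compounds shown cannot separate the two changes. A plain phenyl or a naphthalen-2-yl group on the same oxygen would help to pull them apart.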